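Vinyl to 2-chlorophenyl on the alkoxy chain: working notes

This account rests on a few compounds, and the source may have more. Where it says the series, first, only, none or still open, it means among the compounds named here.

Measured compounds:
compound 1 `CCOC(=O)c1c(C)nc(-c2ccccc2C#N)n1OC` — 14900 nM
compound 2 `C=CCOn1c(-c2cccc(C#N)c2)nc(C)c1C(=O)OCC` — 5860 nM
compound 3 `CCOC(=O)c1c(C)nc(-c2cccc(C#N)c2)n1OCc1cccc(F)c1` — 22400 nM

In a functional assay on a cell-free system (plasma, Oryctolagus cuniculus) for inhibition, with stated times of 5 min, 1 min and 6 min (a higher number here means a weaker inhibitor, a lower number a stronger inhibitor), compound 2 stands lowest of the three numbers. Compound 1 comes next with 14900 nM, a gap beyond the scatter; compound 3 lies furthest, and the single-point step there is a 3.8-fold higher number from compound 2 to compound 3 (0.58 log units; beyond the scatter), a modest weakening.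

Compound 4 `CCOC(=O)c1c(C)nc(-c2cccc(C#N)c2)n1OCc1ccccc1Cl` is still to be measured. It differs from compound 2 in one place only: 2-chlorophenyl in place of vinyl on a saturated chain carbon bound to an oxygen on an aromatic ring. For the measured compounds named here, the one measured step that bears on this place is a 3.8-fold higher number from compound 2 to compound 3 (0.58 log units; beyond the scatter), where an aromatic ring likewise took the place of the vinyl. Going by the values given here, compound 4 carries a 2-chlorophenyl rather than a 3-fluorophenyl, so the two changes are not identical, but the shared move from vinyl to a substituted phenyl is the only guide available. A weakening of similar size is therefore expected; the step expected for compound 4 is a 2.9-fold higher number from compound 2 to compound 4 (0.46 log units; beyond the scatter). Compound 4 is expected to give 17000 nM, within a range from 7000 nM to 40000 nM.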

Compound 4, half-maximal inhibitory concentration: 8710 nM
Compound 4: the middle estimate sits 2.0-fold (0.29 log units) above what was measured, within the range that was stated.
By their numbers in this assay, from the lowest: compounds 2, 4, 1 and 3 (each within the scatter of the next, the first and the last beyond it).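

In this assay, 2-chlorophenyl in place of vinyl on the saturated chain carbon gives a 1.5-fold higher number from compound 2 to compound 4 (0.17 log units; within the scatter) and so leaves the value indistinguishable from that of compound 2, which shows that an aromatic ring at this place does not in itself weaken inhibition, something compound 3 alone could not show. The substituted phenyl groups are not interchangeable here: 2-chlorophenyl in place of 3-fluorophenyl gives a 2.6-fold lower number from compound 3 to compound 4 (0.41 log units; beyond the scatter) and therefore ties the weakening seen with compound 3 to the 3-fluorophenyl group, not to the ring as such. No data at hand explain this difference.

The 3-fluorophenyl and 2-chlorophenyl groups differ in both the halogen and where it sits, and the compounds shown do not separate the two. As far as these compounds go, how an amine, a carboxylic acid or a longer chain would behave at this place remains open.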